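The compounds below may be only part of what the source reports. "The series", "measured", "known", "first", "only" and "open" are said of these compounds alone.

Compound 1 `COc1cc2ncnc(-n3nc(-c4ccccn4)nc3N)c2cc1OCCCNC(=O)CN1C[C@@H](C)O[C@@H](C)C1` gives 34000 nM
Compound 2 `CCOC(=O)NCCCOc1cc2c(-n3nc(-c4ccccn4)nc3N)ncnc2cc1OC` gives 16000 nM

In a physicochemical assay for solubility, in phosphate buffer, with a stated time of 18 h, at pH 7.4 (a lower number here means a less soluble compound, a higher number a more soluble compound), compound 2 stands lower of the two, with 16000 nM against compound 1 at 34000 nM on the same scale. Compound 3 `COc1cc2ncnc(-n3nc(-c4ccccn4)nc3N)c2cc1OCCCNC(=O)OCC(F)(F)F` has not yet been measured there. Its difference from compound 2 is trifluoromethyl in place of methyl on a saturated chain carbon bound to an oxygen next to a carbonyl group in all, which is trifluoromethyl in place of methyl on a saturated chain carbon bound to an oxygen next to a carbonyl group, or, cut one bond further out, ethoxy to 2,2,2-trifluoroethoxy. Going by the values given here, only one measured step bears on this, and only indirectly. It is a 2.1-fold lower number from compound 1 to compound 2 (0.33 log units; beyond the scatter) for ethoxy in place of (2,6-dimethylmorpholin-4-yl)methyl, a modest step. Among the compounds with values here, no measured compound carries trifluoromethyl, so the direction expected here is a tentative judgement. A step of similar modest size is expected, read as a 1.6-fold lower number from compound 2 to compound 3 (0.20 log units; within the scatter) in this estimate. Compound 3 is estimated at 10000 nM in this assay with an expected range from 3500 nM to 24000 nM for its measurement.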

Compound 3, solubility: 100 nM
The estimate for compound 3 lay 100-fold (2.00 log units) above the measured number; the whole stated range lies above it.
By their numbers in this assay, from the lowest: compound 3; then compound 2; then compound 1.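

In this assay, going by these compounds alone, the exchange of methyl for trifluoromethyl on a saturated chain carbon bound to an oxygen next to a carbonyl group gives a 160-fold lower number from compound 2 to compound 3 (2.20 log units; beyond the scatter) and so shows that this position responds strongly to a change of only three fluorine atoms, far more than the modest step among the earlier compounds suggested. Set against compound 1, the exchange of (2,6-dimethylmorpholin-4-yl)methyl for 2,2,2-trifluoroethoxy on a carbonyl carbon gives a 340-fold lower number from compound 1 to compound 3 (2.53 log units; beyond the scatter) and most of that distance lies in the step from ethyl to 2,2,2-trifluoroethyl, not in the step from compound 1 to the ethoxy compound. Nothing reported with these three compounds accounts for the size of this drop.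

The compounds shown leave open whether a monofluoroethoxy or difluoroethoxy group would lower the number in proportion or whether the drop appears only with the full trifluoromethyl group. They also leave open how a longer chain such as propoxy, or an amine such as dimethylamino, would read on the same carbonyl carbon.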